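Chloro-to-hydrogen swap on the pendant phenyl of two cores

The source may hold more compounds than are shown below. What is called first, only, known or untested is meant among the compounds shown, and "the series" means these compounds.

Measured so far in a functional assay on U-87MG ATCC cells for antiproliferative activity against U-87 MG (Homo sapiens), read by MTT assay, with a stated time of 48 h, tested at 5 uM; a lower number here means a stronger effect, a higher number a weaker effect of the compound at the concentration tested:
compound 1 `Cc1nc(-c2ccc(Cl)cc2)sc1C(=O)CSc1nc(-c2ccccc2)c(C#N)c(=O)[nH]1` gives 88.9%
compound 2 `Cc1nc(-c2ccccc2)sc1C(=O)CSc1nc(N)c(C#N)c(-c2ccc(Cl)cc2)n1` gives 62.9%
compound 3 `Cc1nc(-c2ccccc2)sc1C(=O)CSc1nc(-c2ccccc2)c(C#N)c(=O)[nH]1` gives 92.1%

Compound 1 and compound 3 share a core and differ in one place: hydrogen in place of chloro on an aromatic carbon. The step of a number 3.2 percentage points higher from compound 1 to compound 3 (within the scatter) is within the scatter, so in this assay the two numbers of compound 1 and compound 3 cannot be told apart.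

Compound 2 stands on a different core; the difference between the two cores is not broken down here. Its number is the lowest of the three, and its steps to compound 1 and to compound 3 are both beyond the scatter.

Compound 4 `Cc1nc(-c2ccccc2)sc1C(=O)CSc1nc(N)c(C#N)c(-c2ccccc2)n1` is not yet measured. It differs from compound 2 by hydrogen in place of chloro on an aromatic carbon. The place of this change is the same in its printed words as for the change from compound 1 to compound 3, so it is the same kind of change made on another core; the two cores themselves differ in a way not counted here.

The expectation for compound 4 rests on compound 1 and compound 3, whose step a number 3.2 percentage points higher from compound 1 to compound 3 (within the scatter) lay within the scatter, so a step of a number 3.1 percentage points higher from compound 2 to compound 4 (within the scatter) of similar size is expected, with the extra uncertainty that the core of compound 2 is not the core on which the swap was measured. Compound 4 is therefore estimated at 66%, with a range from 50% to 82%.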

Compound 4, a percentage reported as activity, at one concentration (the size of the read-out at that concentration, not a potency): 103%
Compound 4: the middle estimate sits 37 percentage points below what was measured, and the stated range ends below it.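

In this assay, hydrogen in place of chloro on the core of compound 2 gives a step of a number 40.1 percentage points higher from compound 2 to compound 4 (beyond the scatter), so on this core the 4-chlorophenyl compound has the stronger effect at the concentration tested. The change from 4-chlorophenyl to phenyl does not carry over from one core to the other with the same size: the same change on two cores in this assay, a number 3.2 percentage points higher (within the scatter) from compound 1 to compound 3 and a number 40.1 percentage points higher (beyond the scatter) from compound 2 to compound 4, 36.9 percentage points apart, beyond the scatter of two such steps. Within the data shown here, this rests on only two pairs read at a single concentration, so it shows that the size of the swap depends on the structure around it in these compounds, but it gives no general rule for the series, no potency and no reason for the gap.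

As far as these compounds go, it remains open whether the effect on the core of compound 2 is particular to chloro or would also appear with another group in the same place on that aromatic ring, such as fluoro, bromo, methyl or methoxy. From the compounds shown here alone, it is also open whether a further core would follow the small step or the large one, and whether the gap between the two cores would persist at other concentrations in the same cell assay.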